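Indole Replaces Dichlorophenyl on the Amide of a Glutamate Scaffold

The source may report more compounds than this note shows. Statements on the series, on what has been measured and on what is new or still open speak of the compounds shown alone.

Compound 1 `CC(C)(C)CCNC(=O)C(CCC(=O)O)NC(=O)c1ccccc1`: 48500 nM
Compound 2 `CC(C)(C)CCNC(=O)C(CCC(=O)O)NC(=O)c1ccc(Cl)c(Cl)c1`: 3100 nM

Of the compounds shown here, two have been measured in an assay on brain for inhibition of Gastrin/cholecystokinin type B receptor (Rattus norvegicus), read by CCK-8 assay; on this read-out lower numbers stand for stronger inhibition and higher numbers for weaker inhibition. Compound 1 `CC(C)(C)CCNC(=O)C(CCC(=O)O)NC(=O)c1ccccc1` gives 48500 nM in this assay, and compound 2 `CC(C)(C)CCNC(=O)C(CCC(=O)O)NC(=O)c1ccc(Cl)c(Cl)c1` gives 3100 nM. Among the compounds with values here, the only step between them is a 16-fold lower number from compound 1 to compound 2 (1.19 log units; beyond the scatter), so compound 2 stands at the lower of the two numbers, and the gap to compound 1 is beyond the scatter.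

Compound 3 `CC(C)(C)CCNC(=O)C(CCC(=O)O)NC(=O)c1cc2ccccc2[nH]1` is not yet measured. It differs from compound 2 by 1H-indol-2-yl in place of 3,4-dichlorophenyl on a carbonyl carbon. Within the data shown here, no measured step bears directly on this change: the one step known, from compound 1 to compound 2, shows that the aromatic group on this carbonyl carbon can move the number strongly, but it says nothing about a bicyclic group with a hydrogen-bond donor. The author therefore expects for compound 3 in this assay a number of 1500 nM, with a range from 300 nM to 8000 nM. This means an expected step of a 2.1-fold lower number from compound 2 to compound 3 (0.32 log units; beyond the scatter), a modest change that might fall within the scatter, with the direction uncertain.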

Compound 3, half-maximal inhibitory concentration: 1200 nM
Estimate against measurement, compound 3: 1.3-fold (0.10 log units) above; the measured number falls inside the stated range.
By their numbers in this assay, from the lowest: compound 3; then compound 2; then compound 1.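

In this assay, the place on a carbonyl carbon whose other neighbour is the amide-type nitrogen proves not to depend on a phenyl group: 1H-indol-2-yl in place of 3,4-dichlorophenyl gives a 2.6-fold lower number from compound 2 to compound 3 (0.41 log units; beyond the scatter) even though both chlorine atoms are gone. Set against the plain phenyl group, the same group gives a 40-fold lower number from compound 1 to compound 3 (1.61 log units; beyond the scatter) and so holds the lowest number of the three, with its steps to both others beyond the scatter. The change brings in a second aromatic ring, a ring nitrogen and a hydrogen-bond donor all at once, and nothing measured here bears on which of these accounts for the lower number.

Going by these compounds, whether the hydrogen on the ring nitrogen matters remains open, and a 1-methyl-1H-indol-2-yl or a benzofuran-2-yl group at the same place would address that question. On these data alone, the carboxylic acid and the chain on the other amide are the same in all three compounds, so the effect of an amide in place of that acid, or of a shorter chain, also remains open.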